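Branched seven-carbon chain on the shared core

This account rests on a few compounds, and the source may have more. Where it says the series, first, only, none or still open, it means among the compounds named here.

In an assay on isolated protein for inhibition of dual specificity calcium/calmodulin-dependent 3',5'-cyclic nucleotide phosphodiesterase 1A (Bos taurus) (on this read-out higher numbers stand for weaker inhibition and lower numbers for stronger inhibition), compound 2 `CC(C)CCc1nc2c([nH]1)N1C(=N[C@@H]3CCC[C@@H]31)N(C)C2=O` gives 14 nM, the lowest number of the three measured; compound 3 `CCC(CC)c1nc2c([nH]1)N1C(=N[C@@H]3CCC[C@@H]31)N(C)C2=O` gives 150 nM and compound 1 `CCCc1nc2c([nH]1)N1C(=N[C@@H]3CCC[C@@H]31)N(C)C2=O` gives 350 nM. Compound 4 `CCCC(CCC)c1nc2c([nH]1)N1C(=N[C@@H]3CCC[C@@H]31)N(C)C2=O` carries 1-propylbutyl in place of isopentyl on an aromatic carbon. The step bearing most directly on it is an 11-fold higher number from compound 2 to compound 3 (1.03 log units; beyond the scatter), where pentan-3-yl replaced isopentyl. Compound 4 carries the same kind of group with a longer arm on each side, and a 2.3-fold lower number from compound 1 to compound 3 (0.37 log units; beyond the scatter) shows that adding ethyl on the saturated chain carbon bound to the aromatic carbon brings only a modest gain. A large step upward from compound 2 is therefore expected, of about the size seen for compound 3. Compound 4 is estimated at 100 nM, range 30 nM to 400 nM, meaning a 7.1-fold higher number from compound 2 to compound 4 (0.85 log units; beyond the scatter).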

Compound 4, half-maximal inhibitory concentration: 60 nM
The estimate for compound 4 lay 1.7-fold (0.22 log units) above the measured number, and the stated range covers the measured number.
By their numbers in this assay, from the lowest: compound 2; then compound 4; then compound 3; then compound 1.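

In this assay the branched group at this aromatic carbon tolerates longer arms: 1-propylbutyl in place of pentan-3-yl gives a 2.5-fold lower number from compound 3 to compound 4 (0.40 log units; beyond the scatter), so the gain does not stop at compound 3. Against propyl the same group gives a 5.8-fold lower number from compound 1 to compound 4 (0.77 log units; beyond the scatter), yet against isopentyl it still gives a 4.3-fold higher number from compound 2 to compound 4 (0.63 log units; beyond the scatter), so the larger group does not make up the gap to compound 2. Nothing available explains these steps. Still open, on these data alone, is whether a longer chain than isopentyl, such as hexyl, would go lower than compound 2. Equally open, as far as these compounds go, is what a cyclohexyl group or an amine on this carbon would give.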